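A few compounds are considered here, and "the series" means these few. Any claim that something is new, unique, unknown or untested is made for them only; others in the source may bear on it.

Measured compounds in a functional assay on PC-3 cells (Mus musculus) for cytotoxicity against PC-3 (Homo sapiens); a lower number here means a stronger inhibitor, a higher number a weaker inhibitor:
compound 1 `CCCN(CCC)c1c([N+](=O)[O-])cc(S(=O)(=O)Nc2ccc(OC)cc2)cc1[N+](=O)[O-]`: 31000 nM
compound 2 `CCCN(CCC)c1c([N+](=O)[O-])cc(S(=O)(=O)Nc2cccc(Cl)c2)cc1[N+](=O)[O-]`: 18000 nM

Compound 2 stands at the lowest of the two numbers. Among the measured compounds shown here, the only measured step, a 1.7-fold lower number from compound 1 to compound 2 (0.24 log units; within the scatter), lies within the scatter, so the two compounds cannot be ordered. Compound 3 `CCCN(CCC)c1c([N+](=O)[O-])cc(S(=O)(=O)N(C)c2ccccc2)cc1[N+](=O)[O-]` differs from compound 2 by methyl(phenyl)amino in place of (3-chlorophenyl)amino on a sulfonyl sulfur. That earlier step touched the same place on the sulfonyl sulfur, yet nothing measured speaks to the loss of the hydrogen-bond donor here. Compound 3 is therefore expected near compound 2, with a step of a 1.2-fold higher number from compound 2 to compound 3 (0.09 log units; within the scatter) not beyond the scatter, at an estimated 22000 nM in the range 7000 nM to 70000 nM.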

Compound 3, half-maximal inhibitory concentration: > 100000 nM
Compound 3: a limit, no number (the forecaster's own chance of this, stated with the estimate: 15%); middle value at least 4.5-fold (0.65 log units) away from the limit.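

The position on the sulfonyl sulfur now shows a change beyond the scatter in this assay, with an at least 5.5-fold higher number from compound 2 to compound 3 (0.74 log units; beyond the scatter) and an at least 3.2-fold higher number from compound 1 to compound 3 (0.50 log units; beyond the scatter). For compound 3, > 100000 nM is a limit of the assay and not a number: the limit of > 100000 nM in this assay, at which 1 of the 3 values shown sits. Methyl(phenyl)amino has no hydrogen-bond donor where the (3-chlorophenyl)amino of compound 2 has one, but its ring also lacks the chlorine, so these two differences travel together.

The compounds shown leave open which difference goes with the step. Plain phenylamino or (3-chlorophenyl)(methyl)amino on the sulfonyl sulfur would separate them.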